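Free fraction on replacing cyclopentyl in compound 1

A few compounds are considered here, and "the series" means these few. Any claim that something is new, unique, unknown or untested is made for them only; others in the source may bear on it.

Measured in an ADME assay on a cell-free system (plasma, Rattus norvegicus) (on this read-out higher numbers stand for a larger free fraction and lower numbers for a smaller free fraction), so far
- compound 1 `CC(=O)Nc1cc(-c2ccc(N(C)C(=O)c3c(F)cccc3Cl)c(N3CC4CC4C3)c2)n(C2CCCC2)n1` reads < 0.0005 as a limit, not a number
- compound 2 `CN(C(=O)c1c(F)cccc1Cl)c1ccc(-c2cc(C(N)=O)ccc2Cl)cc1OCC(F)(F)F` reads 0.002 as a number

Compound 1 stands at a limit of this assay and has no exact value. Compound 3 `CC(=O)Nc1cc(-c2ccc(N(C)C(=O)c3c(F)cccc3Cl)c(N3CC4CC4C3)c2)n(CC2CC2)n1` has cyclopropylmethyl in place of cyclopentyl on an aromatic nitrogen and is otherwise unchanged. Among the compounds with values here, no measured pair isolates this change. A small step towards a larger free fraction is expected in this assay and is estimated as an at least 1.6-fold higher number from compound 1 to compound 3 (0.20 log units; that floor lies within the scatter) for now. The expected value for compound 3 is 0.0008 within a range from 0.0003 to 0.002 and may again prove to be only a limit.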

Compound 3, unbound fraction: 0.002
The estimate for compound 3 lay 2.5-fold (0.40 log units) below the measured number; the measured number falls inside the stated range.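

On the aromatic nitrogen, cyclopropylmethyl in place of cyclopentyl gives, in this assay, an at least 4.0-fold higher number from compound 1 to compound 3 (0.60 log units; beyond the scatter). This position therefore moves the free fraction even with carbon-only groups on both sides of the change, neither carrying hydrogen-bond donors or acceptors. The size of the step remains a floor because compound 1 stands at a limit, not a number: the limit of < 0.0005 in this assay, at which 1 of the 3 values shown sits.

As far as these compounds go, whether an amine, a carboxylic acid or a longer chain on this nitrogen would shift this assay further remains open. From the compounds shown here alone, whether the step carries over to another core also remains open.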